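A few compounds are considered here, and "the series" means these few. Any claim that something is new, unique, unknown or untested is made for them only; others in the source may bear on it.

Measured in this series:
compound 1 `Cn1nc2c(=O)n(CC3(O)CCN(Cc4ccc(-c5ccco5)cc4Cl)CC3)cnc2c1-c1ccc(CNC(=O)C(F)(F)F)cc1` — 2060 nM
compound 2 `CC(C)NCc1ccc(-c2c3ncn(CC4(O)CCN(Cc5ccc(-c6ccco6)cc5Cl)CC4)c(=O)c3nn2C)cc1` — 29.1 nM
compound 3 `Cn1nc2c(=O)n(CC3(O)CCN(Cc4ccc(-c5ccco5)cc4Cl)CC3)cnc2c1-c1ccc(C(F)(F)F)cc1` — 530 nM

In an assay on isolated protein for inhibition of ubiquitin carboxyl-terminal hydrolase 7 (Homo sapiens), with stated times of 30 min and 2 h (a lower number here means a stronger inhibitor, a higher number a weaker inhibitor), compound 3 stands second highest of the three numbers. Its nearest neighbour is given by a 3.9-fold lower number from compound 1 to compound 3 (0.59 log units; beyond the scatter), its furthest by an 18-fold higher number from compound 2 to compound 3 (1.26 log units; beyond the scatter).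

Compound 4 `Cn1nc2c(=O)n(CC3(O)CCN(Cc4ccc(-c5ccco5)cc4Cl)CC3)cnc2c1-c1ccc(CO)cc1` differs from compound 3 by hydroxymethyl in place of trifluoromethyl on an aromatic carbon. Among the compounds with values here, no measured step exchanges exactly these two groups. The steps that vary the same aromatic carbon are an 18-fold higher number from compound 2 to compound 3 (1.26 log units; beyond the scatter) (large) and a 3.9-fold lower number from compound 1 to compound 3 (0.59 log units; beyond the scatter) (modest); both changes moved the number well beyond the scatter, so this position is sensitive. Hydroxymethyl carries neither the (isopropylamino)methyl of compound 2 nor the (((trifluoromethyl)carbonyl)amino)methyl of compound 1. A small shift toward a higher number is therefore expected, a 1.4-fold higher number from compound 3 to compound 4 (0.15 log units; within the scatter), within wide bounds. Compound 4 is estimated at 750 nM, range 250 nM to 2200 nM.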

Compound 4, half-maximal inhibitory concentration: 42.5 nM
The estimate for compound 4 lay 18-fold (1.25 log units) above the measured number, outside the stated range (below it).
By their numbers in this assay, from the lowest: compounds 2 and 4 (each within the scatter of the next); then compound 3; then compound 1.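

In this assay this aromatic carbon accepts hydroxymethyl far better than trifluoromethyl (a 12-fold lower number from compound 3 to compound 4 (1.10 log units; beyond the scatter)), so a low number here does not depend on a chain amine. Hydroxy and isopropylamino on the chain carbon are not separated (a 1.5-fold higher number from compound 2 to compound 4 (0.16 log units; within the scatter)), whereas ((trifluoromethyl)carbonyl)amino stands well apart from hydroxy (a 48-fold lower number from compound 1 to compound 4 (1.69 log units; beyond the scatter)). No measurement offered here accounts for these steps.

Open, going by these compounds, is whether the hydroxy hydrogen matters, which a methoxymethyl group on this carbon would test. A carboxylic acid or a longer hydroxyethyl chain at the same place would show how far this tolerance extends.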